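From methyl to cyclohexyl on a double-bonded nitrogen

The compounds below may be only part of what the source reports. "The series", "measured", "known", "first", "only" and "open" are said of these compounds alone.

Three compounds have been measured in a functional assay on the whole organism (blood, strain Wistar-Okamoto) with Rattus norvegicus as the target, with a stated time of 5 days; a lower number here means that less compound is needed, a higher number that more compound is needed for the effect:
Compound 1 `C/N=C(\NC#N)Nc1cccnc1`: > 50 mg/kg
Compound 2 `CC(C)C/N=C(\NC#N)Nc1cccnc1`: 20 mg/kg
Compound 3 `N#CN/C(=N\C1CCCC1)Nc1cccnc1`: 20 mg/kg

Compound 1 stands only at a limit of this assay, namely (the limit of > 50 mg/kg in this assay, at which 1 of the 3 values shown sits). Compound 4 `N#CN/C(=N\C1CCCCC1)Nc1cccnc1` differs from compound 1 in cyclohexyl in place of methyl on a double-bonded nitrogen. Among the measured compounds shown here, two measured steps bear on this change: an at least 2.5-fold lower number from compound 1 to compound 2 (0.39 log units; beyond the scatter) and an at least 2.5-fold lower number from compound 1 to compound 3 (0.39 log units; beyond the scatter). Between the two larger groups there was no change at the digits printed from compound 2 to compound 3 (within the scatter), so the cyclohexyl of compound 4 is expected to behave like the cyclopentyl of compound 3. A step in the same direction and of similar size is therefore expected, an at least 2.5-fold lower number from compound 1 to compound 4 (0.39 log units; beyond the scatter). Compound 4 is estimated at 20 mg/kg, with a range from 10 mg/kg to 50 mg/kg.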

Compound 4, minimum effective dose: 20 mg/kg
Beside the measured number, compound 4's estimate shows no gap at the digits printed; the range from low to high includes it.
By their numbers in this assay, from the lowest: compounds 2, 3 and 4 (each within the scatter of the next). At a limit, above all of these: compound 1.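

In this assay, cyclohexyl on the double-bonded nitrogen gives an at least 2.5-fold lower number from compound 1 to compound 4 (0.39 log units; beyond the scatter), so the gain seen with isobutyl and cyclopentyl also holds for this six-membered ring. Against those two groups there is no change at the digits printed from compound 3 to compound 4 (within the scatter) and no change at the digits printed from compound 2 to compound 4 (within the scatter), so the three groups cannot be told apart at this position.

On these data alone, the full size of the step from methyl stays open, since compound 1 stands only at a limit: the limit of > 50 mg/kg in this assay, at which 1 of the 4 values shown sits. Also open, as far as these compounds go, is whether a longer chain, a phenyl ring or an amine at this place would keep the same number.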